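Sulfonyl aryl variation in a bradykinin B1 antagonist series

The compounds below may be only part of what the source reports. "The series", "measured", "known", "first", "only" and "open" are said of these compounds alone.

Measured so far:
compound 1 `CN(Cc1ccc(C2=NCCN2)cc1)C(=O)COCCN(C)S(=O)(=O)c1ccccc1C#N`: 6
compound 2 `CN(Cc1ccc(C2=NCCN2)cc1)C(=O)COCCN(C)S(=O)(=O)c1c(Cl)cccc1Cl`: 7.2
compound 3 `Cc1c(Cl)ccc(S(=O)(=O)N(C)CC(=O)NCC(=O)N(C)Cc2ccc(C3=NCCN3)cc2)c1Cl`: 6.4

Three compounds have been run in a functional assay for antagonist activity at B1 bradykinin receptor (Mus musculus), using Schild analysis, with a stated time of 30 min (on this read-out higher numbers stand for higher potency (the scale is a negative logarithm) and lower numbers for lower potency), and compound 2 gives the highest number of the three; compound 3 with 6.4 and compound 1 with 6 both sit clearly below it. Compound 4 `COc1ccc(S(=O)(=O)N(C)CCOCC(=O)N(C)Cc2ccc(C3=NCCN3)cc2)c(C)c1` has not yet been measured in this assay. It departs from compound 2 on the sulfonyl sulfur: 4-methoxy-2-methylphenyl in place of 2,6-dichlorophenyl on a sulfonyl sulfur.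

For the measured compounds named here, only one measured step touches that same position. Going from the 2-cyanophenyl to the 2,6-dichlorophenyl on the sulfonyl sulfur, the assay moved a number 1.20 log units higher from compound 1 to compound 2 (beyond the scatter), so the aryl group on this sulfur matters a great deal for potency in this series. The 4-methoxy-2-methylphenyl is neither of the two groups already tried, so the direction is not fixed by the data, but since the 2,6-dichlorophenyl is the best of the three aryl groups seen, a drop from compound 2 is the more likely outcome. For compound 4 the expected change in this assay is a number 0.70 log units lower from compound 2 to compound 4 (beyond the scatter), a loss of moderate size with wide uncertainty. Compound 4 is therefore estimated at 6.5, with a range from 5.8 to 7.2.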

Compound 4, negative logarithm of the antagonist equilibrium constant: 6.9
Beside the measured number, compound 4's estimate is 0.40 log units below it; low and high end bracket the measured number.
By their numbers in this assay, from the lowest: compound 1; then compound 3; then compounds 4 and 2 (each within the scatter of the next).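

In this assay, the sulfonyl sulfur accepts a quite different aryl group without a clear change: with 4-methoxy-2-methylphenyl in place of 2,6-dichlorophenyl, the step is a number 0.30 log units lower from compound 2 to compound 4 (within the scatter). Chlorine on the ring is therefore not needed to stay at this level, and a methoxy and a methyl group serve within the scatter. The 2-cyanophenyl now stands apart from two aryl groups rather than one, with a number 0.90 log units higher from compound 1 to compound 4 (beyond the scatter) alongside a number 1.20 log units higher from compound 1 to compound 2 (beyond the scatter), so among these three compounds with the same chain, only compound 1 lies clearly lower. Nothing at hand accounts for these differences or for the match between the two quite different aryl groups.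

As far as these compounds go, it remains open whether the methoxy or the methyl group of the 4-methoxy-2-methylphenyl matters more, and whether a plain phenyl, a naphthyl group or a pyridine ring on the sulfonyl sulfur would group with compound 1 or with compounds 2 and 4. From the compounds shown here alone, it is equally open whether this tolerance carries over to the different chain of compound 3.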